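A few compounds are considered here, and "the series" means these few. Any claim that something is new, unique, unknown or untested is made for them only; others in the source may bear on it.

Series notes. Compound 1 `C=CCSc1nncc2cnc(C)n12`, compound 2 `Cc1ncc2cnnc(O)n12` and compound 3 `Cc1nc(C)n2c(O)nncc12` have been run in a functional assay for inhibition, with Homo sapiens as the target; on this read-out lower numbers stand for stronger inhibition and higher numbers for weaker inhibition; compound 4 `C=CCSc1nncc2c(C)nc(C)n12` remains to be measured. In this assay compound 1 gives 61000 nM. For compound 2 this assay reports only a limit, > 48000 nM. For compound 3 likewise only a limit is reported, > 48000 nM. The change from compound 2 to compound 1, (allylsulfanyl in place of hydroxy on an aromatic carbon), gives a step that the limit leaves unreadable from compound 2 to compound 1. The cores of compound 2 and compound 3 differ by methyl in place of hydrogen on an aromatic carbon, with a step that the two limits leave unreadable from compound 2 to compound 3. Both steps stay unreadable because of the limit of > 48000 nM in this assay, at which 2 of the 3 values shown sit. The change from compound 3 to compound 4, (allylsulfanyl in place of hydroxy on an aromatic carbon), is the same change as that from compound 2 to compound 1. Compound 4 is expected near 70000 nM, between 30000 nM and 200000 nM. That expectation rests on compound 1, which gives 61000 nM in this assay, so weak inhibition is expected. The step that the limit leaves unreadable from compound 3 to compound 4 is expected to be small and may itself be unreadable.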

Compound 4, half-maximal inhibitory concentration: 59000 nM
Estimate against measurement, compound 4: 1.2-fold (0.07 log units) above; the measured number falls inside the stated range.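

In this assay, methyl in place of hydrogen on an aromatic carbon, read on the allylsulfanyl compounds, gives a 1.0-fold lower number from compound 1 to compound 4 (0.01 log units; within the scatter). For the compounds shown here, this is the only readable step, and it shows one pair only, so it does not show that the methyl change behaves alike on the hydroxy compounds. The steps for that change on the hydroxy compounds and for allylsulfanyl in place of hydroxy on either core cannot be read, and no comparison across cores is possible because of the assay limit: the limit of > 48000 nM in this assay, at which 2 of the 4 values shown sit.

Still open, as far as these compounds go, is how an amine or a longer chain in place of allylsulfanyl would read in this assay. Also open, from the compounds shown here alone, is how ethyl in place of the added methyl would read.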